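Methylsulfanyl for Chloro on Two Related Cores

The compounds below may be only part of what the source reports. "The series", "measured", "known", "first", "only" and "open" are said of these compounds alone.

In a functional assay on the whole organism for inhibition, with Digitaria ciliaris as the target, with a stated time of 72 h, tested at 10 mg/L (on this read-out higher numbers stand for more inhibition of growth at the one concentration tested and lower numbers for less inhibition of growth), compound 1, `COc1cc(SC)nc(NC(=S)NC(=O)c2c(-c3ccc(Cl)cc3Cl)noc2C)n1`, gives 34.8%.
In this assay compound 2, `COc1cc(Cl)nc(NC(=S)NC(=O)c2c(-c3ccc(Cl)cc3Cl)noc2C)n1`, gives 14.6%.
In this assay compound 3, `COc1cc(Cl)nc2n/c(=N/C(=O)c3c(-c4ccc(Cl)cc4Cl)noc3C)sn12`, gives 16.5%.

Compound 1 and compound 2 share one core and differ in a single place: methylsulfanyl in place of chloro on an aromatic carbon. That exchange produced the step of a number 20.2 percentage points higher from compound 2 to compound 1 (beyond the scatter). Compound 3 carries a different core; the difference between the two cores of compound 2 and compound 3 is not broken down here. Compound 4, `COc1cc(SC)nc2n/c(=N/C(=O)c3c(-c4ccc(Cl)cc4Cl)noc3C)sn12`, has not yet been measured and relates to compound 3 as compound 1 relates to compound 2: methylsulfanyl in place of chloro on an aromatic carbon. The surroundings are not identical, since in compound 4 the ring is part of a fused or bridged system of two rings and the carbon is meta to a fused ring and para to a fused ring, whereas in compound 2 it is meta to a large group; this is the same kind of change, not the same change. The step from compound 3 to compound 4 is expected to be a number 18.5 percentage points higher from compound 3 to compound 4 (beyond the scatter) because the earlier step of a number 20.2 percentage points higher from compound 2 to compound 1 (beyond the scatter) came from the same kind of change. Compound 4 is therefore expected to give about 35% in this assay, likely between 20% and 50%.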

Compound 4, percent growth inhibition at one concentration: 19.8%
Compound 4: the middle estimate sits 15.2 percentage points above what was measured; measured number below the stated range.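

In this assay, methylsulfanyl in place of chloro on the core of compound 3 gave a number 3.3 percentage points higher from compound 3 to compound 4 (within the scatter), so the exchange did not repeat the size of the step seen on the other core. The same exchange therefore gave two different results on the two cores: the same change on two cores in this assay, a number 20.2 percentage points higher (beyond the scatter) from compound 2 to compound 1 and a number 3.3 percentage points higher (within the scatter) from compound 3 to compound 4, 16.9 percentage points apart, beyond the scatter of two such steps. Among the compounds shown here, this shows that, in this series, a gain from this exchange on one core cannot simply be assumed on the other, but with only one pair on each core it does not show why the results differ, or whether the gap would persist at another concentration or on another plant species.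

The compounds shown carry only chloro or methylsulfanyl at this place, which leaves open what an amine or a longer chain such as propylsulfanyl would do there. As far as these compounds go, it also remains open whether such groups would act alike on the two cores or would again give different results.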